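This account rests on a few compounds, and the source may have more. Where it says the series, first, only, none or still open, it means among the compounds named here.

Two compounds with the same core, differing only in their saturated chain, have numbers in a functional assay, with a stated time of 10 min; on this read-out higher numbers stand for weaker inhibition and lower numbers for stronger inhibition. Compound 1 (`CCCCCCCCCCCCOc1cc(OC)c(Br)cc1C(C)=O`) gives 23100000 nM, and compound 2 (`CCCCCCCCCCCCCCOc1cc(OC)c(Br)cc1C(C)=O`) gives 13200000 nM. The step between them is a 1.8-fold lower number from compound 1 to compound 2 (0.24 log units; within the scatter), so compound 2 stands level with compound 1 on these numbers, and the pair shows no real difference.

Compound 3 (`CCCCCCCCCCCCCCOc1cc(OC)ccc1C(C)=O`) keeps the chain of compound 2 and changes at a different place on the molecule: hydrogen in place of bromo on an aromatic carbon. In words, this is hydrogen in place of bromo on an aromatic carbon.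

Going by the values given here, no measured pair tests this swap. Among the compounds with values here, the one measured step concerns the chain, not the bromo, so it suggests neither a size nor a direction for this change. The expectation therefore starts from compound 2 at 13200000 nM, and no shift beyond the scatter is expected in this assay, although the uncertainty is wide.

The expected change is a 1.1-fold higher number from compound 2 to compound 3 (0.06 log units; within the scatter). For compound 3 the estimated value is 15000000 nM, with an expected range from 5000000 nM to 40000000 nM.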

Compound 3, half-maximal inhibitory concentration: 57000000 nM
Compound 3: the middle estimate sits 3.8-fold (0.58 log units) below what was measured; the measured number lies above the stated range.
By their numbers in this assay, from the lowest: compounds 2 and 1 (each within the scatter of the next); then compound 3.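

Bromo at this position matters in this assay in a way the chain change did not: hydrogen in place of bromo on this aromatic carbon, ortho to a methoxy group and meta to an acetyl group, gives a 4.3-fold higher number from compound 2 to compound 3 (0.64 log units; beyond the scatter) and so means weaker inhibition. The chain change gave only a 1.8-fold lower number from compound 1 to compound 2 (0.24 log units; within the scatter) and showed no real difference, so among the compounds shown this aromatic carbon is the one place where a change moves the number beyond the scatter. Nothing available here explains why the number rises when the bromo leaves.

The compounds shown carry only bromo or hydrogen at this position, so it remains open whether chloro, fluoro, methyl or a nitrile there would sit closer to compound 2 or to compound 3. On these data alone, it also remains open whether the loss seen on removing the bromo would be of similar size with the dodecyl-length chain of compound 1, or in a molecule with a carboxylic acid in place of the acetyl group.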